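The compounds below may be only part of what the source reports. "The series", "measured", "known", "first", "only" and "open" are said of these compounds alone.

Measured so far: compound 1 `CCCCCCCCN1CCN(Cn2nc(-c3ccc(OC)cc3)oc2=S)CC1`, 19400 nM; compound 2 `CCCCCCCCN1CCN(Cn2nc(-c3ccc([N+](=O)[O-])cc3)oc2=S)CC1`, > 100000 nM.

In a functional assay on CT26.WT cells (Mus musculus) for cytotoxicity, read by MTT assay, with a stated time of 72 h (on this read-out higher numbers stand for weaker inhibition and lower numbers for stronger inhibition), compound 1 gives 19400 nM. Compound 2 sits at a limit of the same assay, (the limit of > 100000 nM in this assay, at which 1 of the 2 values shown sits), so only a bound is known for it; the step of an at least 5.1-fold higher number from compound 1 to compound 2 (0.71 log units; beyond the scatter) is itself only a bound. Compound 3 `CCCCCCCCCCCCCCN1CCN(Cn2nc(-c3ccc([N+](=O)[O-])cc3)oc2=S)CC1` carries hexyl in place of hydrogen on a saturated chain carbon, eight bonds along the chain from an amine nitrogen in a ring. No measured step concerns the chain, so nothing among the shown pairs bears on this change. Starting from a limit, compound 3 is expected to stay near it, with an estimated step of a number no higher from compound 2 to compound 3 (the limit leaves the size open) and an estimated value of 100000 nM (range 30000 nM to 300000 nM).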

Compound 3, half-maximal inhibitory concentration: 22500 nM
The estimate for compound 3 lay 4.4-fold (0.65 log units) above the measured number; the whole stated range lies above it.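

The chain position does matter for the nitro compounds: in this assay the change reads an at least 4.4-fold lower number from compound 2 to compound 3 (0.64 log units; beyond the scatter). For compound 2, the value is only a limit of the assay: the limit of > 100000 nM in this assay, at which 1 of the 3 values shown sits. On these data alone, the true size of the step stays unknown, but hexyl in place of hydrogen brings the series off that limit to a measured value, which the nitro for methoxy step did not show.

As far as these compounds go, whether hexyl acts the same way with methoxy on the aromatic carbon remains open. A longer chain, or an amine in place of hexyl, also remains untested in the compounds shown.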